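This account rests on a few compounds, and the source may have more. Where it says the series, first, only, none or still open, it means among the compounds named here.

Series notes on an ADME assay on Vero cells (Chlorocebus sabaeus) for cytotoxicity, read by MTT assay, with a stated time of 72 h; a higher number here means a weaker inhibitor, a lower number a stronger inhibitor. Compound 1 `O=C(c1ccncc1)N1N=C(c2cc3ccccc3o2)CC1c1ccccc1Cl` carries a chloro group, and compound 2 `O=C(c1ccncc1)N1N=C(c2cc3ccccc3o2)CC1c1ccccc1[N+](=O)[O-]` is the same core after nitro in place of chloro on an aromatic carbon. In this assay compound 1 reaches only a limit, > 210000 nM. Compound 2 likewise gives only a limit, > 245000 nM. The step that the two limits leave unreadable from compound 1 to compound 2 cannot be read because the limit of > 210000 nM in this assay, at which 1 of the 3 values shown sits, and the limit of > 245000 nM in this assay, at which 1 of the 3 values shown sits, cap both values. Compound 3 `CCn1cc(C(=O)N2N=C(c3cc4ccccc4o3)CC2c2ccccc2Cl)c(=O)c2ccc(C)nc21` carries a different amide portion; how its core differs from the core of compound 1 is not broken down here. In this assay compound 3 also gives only a limit, > 178000 nM, which is the limit of > 178000 nM in this assay, at which 1 of the 3 values shown sits. Compound 4 `CCn1cc(C(=O)N2N=C(c3cc4ccccc4o3)CC2c2ccccc2[N+](=O)[O-])c(=O)c2ccc(C)nc21` is compound 3 with the same change, (nitro in place of chloro on an aromatic carbon), at the same place as before. For compound 4 the expected step is a step that the limit leaves unreadable from compound 3 to compound 4, resting on a step that the two limits leave unreadable from compound 1 to compound 2 and on compound 3 standing at its limit > 178000 nM. Compound 4 is therefore expected at 250000 nM, most likely again reported only as a limit, within 100000 nM to 1000000 nM.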

Compound 4, half-maximal inhibitory concentration: > 85400 nM
Compound 4: only a limit was reported (the forecaster's own chance of this, stated with the estimate: 85%); the middle value lies beyond the limit too.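

In this assay compound 4 gives only a limit, > 85400 nM. The step from compound 3 to compound 4 cannot be read: both values are limits. The compounds shown leave open whether nitro in place of chloro shifts the half-maximal inhibitory concentration in this assay with either amide portion; all four values are limits.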